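The source may hold more compounds than are shown below. What is called first, only, known or untested is meant among the compounds shown, and "the series" means these compounds.

Of the compounds shown here, three sharing one core have been tested in a functional assay on PC-3 cells (Homo sapiens) for inhibition, read by CellTiter-Glo, with a stated time of 72 h; on this read-out lower numbers stand for higher toxicity in this test and higher numbers for lower toxicity in this test. Compound 1 `CC1=C(C(C)C(=O)N(C)CCN(C)C)c2cc(F)ccc2/C1=C\c1ccc([S+](C)[O-])cc1` gives 44600 nM. Compound 3 `CC1=C(C(C)C(=O)N(C)CCN(C)C(=O)[C@@H](N)C(C)C)c2cc(F)ccc2/C1=C\c1ccc([S+](C)[O-])cc1` gives 28800 nM. For compound 2 `CC1=C(C(C)C(=O)N2CCN(CCCN(C)C)CC2)c2cc(F)ccc2/C1=C\c1ccc([S+](C)[O-])cc1` the test reports only a limit, > 50000 nM. Of the two real numbers, compound 3 holds the lower one, yet its gap to compound 1 stays within the usual scatter of repeated runs, so the two cannot be ranked. The measured steps were both small: an at least 1.1-fold higher number from compound 1 to compound 2 (0.04 log units; that floor lies within the scatter), and a 1.5-fold lower number from compound 1 to compound 3 (0.19 log units; within the scatter). Compound 4 `CC1=C(C(C)C(=O)N(C)CCN(C)C(=O)[C@@H]2CCCN2)c2cc(F)ccc2/C1=C\c1ccc([S+](C)[O-])cc1` has not yet been measured. It differs from compound 3 in one place: pyrrolidin-2-yl in place of 1-amino-2-methylpropyl on a carbonyl carbon. One cap on the amide-type nitrogen is thus exchanged for a ring-shaped cap of similar build. The most comparable measured change, a 1.5-fold lower number from compound 1 to compound 3 (0.19 log units; within the scatter), stayed within the scatter. The expected step is therefore small, a 1.0-fold higher number from compound 3 to compound 4 (0.02 log units; within the scatter), with no direction favoured beyond the scatter. Compound 4 is estimated at 30000 nM, with a likely range from 14000 nM to 60000 nM.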

Compound 4, half-maximal cytotoxic concentration: 27900 nM
Compound 4: middle estimate off by 1.1-fold (0.03 log units), on the high side, and the stated range covers the measured number.
By their numbers in this assay, from the lowest: compounds 4, 3 and 1 (each within the scatter of the next). At a limit, above all of these: compound 2.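

In this assay, the open 1-amino-2-methylpropyl on the carbonyl carbon and the ring-closed pyrrolidin-2-yl cannot be told apart (a 1.0-fold lower number from compound 3 to compound 4 (0.01 log units; within the scatter)), so tying this group into a five-membered ring makes no readable difference. The new result also adds a second cap at this place: the (pyrrolidin-2-yl)carbonyl group in place of methyl on the amine nitrogen stays within the scatter as well (a 1.6-fold lower number from compound 1 to compound 4 (0.20 log units; within the scatter)), as did the open-chain cap of compound 3. Nothing given here bears on why these values lie so close together.

All three real numbers lie within the scatter of their neighbours, so no change at this place has yet given a readable step. On these data alone, whether a phenyl ring, a carboxylic acid or a longer amine chain on this carbonyl carbon would do so remains open.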